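Trimming the Alkynyl Arm from a Weak Antiproliferative Core

A few compounds are considered here, and "the series" means these few. Any claim that something is new, unique, unknown or untested is made for them only; others in the source may bear on it.

Compound 1 `O=c1nc2oc(CCCCl)c(C#CCCCCl)c2cn1Cc1cn(Cc2ccccc2)nn1`: 32800 nM
Compound 2 `CCCCCc1ccc(C#Cc2c(-c3ccc(CCCCC)cc3)oc3nc(=O)n(Cc4cn(Cc5ccccc5)nn4)cc23)cc1`: > 100000 nM

In a functional assay on CFPAC-1 cells (Homo sapiens) for antiproliferative activity, read by MTT assay, with a stated time of 72 h (on this read-out lower numbers stand for stronger inhibition and higher numbers for weaker inhibition), compound 1 gives 32800 nM, the only numbered result among the two compounds measured. Compound 2 reaches only (the limit of > 100000 nM in this assay, at which 1 of the 2 values shown sits), a limit of the assay and not a number. Compound 3 `O=c1nc2oc(CCCCl)cc2cn1Cc1cn(Cc2ccccc2)nn1` is not yet measured; it differs from compound 1 by hydrogen in place of 5-chloropent-1-yn-1-yl on an aromatic carbon. Among the measured compounds shown here, with no measured step of this kind to lean on, the expected change is small, a loss within or just beyond the scatter, estimated as a 1.7-fold higher number from compound 1 to compound 3 (0.22 log units; within the scatter). Compound 3 is therefore expected near 55000 nM, between 18000 nM and 160000 nM.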

Compound 3, half-maximal inhibitory concentration: 23500 nM
Compound 3: the middle estimate sits 2.3-fold (0.37 log units) above what was measured, and the stated range covers the measured number.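

Replacing the 5-chloropent-1-yn-1-yl group with hydrogen in this assay gives a 1.4-fold lower number from compound 1 to compound 3 (0.14 log units; within the scatter) and so leaves the number within the scatter. The whole arm on this aromatic carbon can therefore go without a measurable cost, and the core of compound 1 holds its weak level without it. Nothing measured here explains this step.

On these data alone, whether an amine, a carboxylic acid or a shorter chain on this carbon would move the number stays open. So does the part played by the 3-chloropropyl group.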